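Compound 3 and the expected step to compound 4

The source may report more compounds than this note shows. Statements on the series, on what has been measured and on what is new or still open speak of the compounds shown alone.

Compound 1 `CC(=O)NC[C@H]1CN(c2ccc(-c3ccc(/C=N/N4CCN(C)CC4)nc3)c(F)c2)C(=O)O1`: 95.8%
Compound 2 `CC(=O)NC[C@H]1CN(c2ccc(-c3ccc(/C=N/N4CCSCC4)nc3)c(F)c2)C(=O)O1`: 98%
Compound 3 `CC(=O)NC[C@H]1CN(c2ccc(-c3ccc(/C=N/N4CCN(C)CC4)c(O)c3)c(F)c2)C(=O)O1`: 5.3%

In an ADME assay for metabolic stability, with a stated time of 2 h, at pH 1.2 (on this read-out higher numbers stand for a more stable compound and lower numbers for a less stable compound), compound 3 stands lowest of the three, well apart from the other two. Compound 4 `CC(=O)NC[C@H]1CN(c2ccc(-c3ccc(/C=N/N4CCSCC4)c(O)c3)c(F)c2)C(=O)O1` differs from it by one exchange: thiomorpholin-4-yl in place of 4-methylpiperazin-1-yl on a double-bonded nitrogen. This puts thiomorpholin-4-yl in place of 4-methylpiperazin-1-yl on a double-bonded nitrogen. The same exchange has been measured only once, as a number 2.2 percentage points higher from compound 1 to compound 2 (within the scatter). That step was taken on a different core and near the top of the scale, so it is only a loose guide here. No step beyond the scatter is therefore expected in this assay. The expected change is a number 2.2 percentage points higher from compound 3 to compound 4 (within the scatter). Compound 4 is estimated at 7.5%, within a range from 1% to 25%.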

Compound 4, percent of the compound remaining: 75.9%
Estimate against measurement, compound 4: 68.4 percentage points below; the whole stated range lies below it.
By their numbers in this assay, from the lowest: compound 3; then compound 4; then compounds 1 and 2 (each within the scatter of the next).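

In this assay, thiomorpholin-4-yl in place of 4-methylpiperazin-1-yl on a double-bonded nitrogen is not a neutral exchange on every core: on the core of compound 3 it gives a number 70.6 percentage points higher from compound 3 to compound 4 (beyond the scatter). The size of this change therefore differs with the core that carries it, which the earlier pair alone could not show: the same change on two cores in this assay, a number 2.2 percentage points higher (within the scatter) from compound 1 to compound 2 and a number 70.6 percentage points higher (beyond the scatter) from compound 3 to compound 4, 68.4 percentage points apart, beyond the scatter of two such steps

The compounds shown leave open whether morpholin-4-yl at this place on the core of compound 3 would end nearer compound 3 or compound 4. They also cannot tell what in the two cores sets the steps apart.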